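Five-membered heteroaryl swaps on the shared biaryl core

The compounds below may be only part of what the source reports. "The series", "measured", "known", "first", "only" and "open" are said of these compounds alone.

For the measured compounds named here, compound 3 `c1ccc(-c2ccns2)c(OCC2=NCCN2)c1` gives 5.01 nM in a functional assay for activation of Alpha-1A adrenergic receptor (Homo sapiens), read by calcium flux (a higher number here means that more compound is needed for the effect, a lower number that less compound is needed), the highest of the three numbers measured so far. Compound 1 `c1c[nH]c(-c2ccccc2OCC2=NCCN2)c1` gives 1.26 nM and compound 2 `c1ccc(-c2ccoc2)c(OCC2=NCCN2)c1` gives 0.501 nM in this assay. Compound 4 `c1ccc(-c2ncc[nH]2)c(OCC2=NCCN2)c1` differs from compound 3 by 1H-imidazol-2-yl in place of 1,2-thiazol-5-yl on an aromatic carbon. Going by the values given here, two measured steps bear on this change: a 4.0-fold higher number from compound 1 to compound 3 (0.60 log units; beyond the scatter) and a 10-fold higher number from compound 2 to compound 3 (1.00 log units; beyond the scatter). Read the other way, each exchange of the 1,2-thiazol-5-yl for another five-membered ring lowered the number. The entering 1H-imidazol-2-yl carries one hydrogen-bond donor, as does the 1H-pyrrol-2-yl of compound 1, whose value of 1.26 nM points to a modest drop. The expected step is a 2.5-fold lower number from compound 3 to compound 4 (0.40 log units; beyond the scatter). Compound 4 is therefore estimated at 2 nM, with a range from 0.5 nM to 8 nM.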

Compound 4, half-maximal effective concentration: 100 nM
Beside the measured number, compound 4's estimate is 50-fold (1.70 log units) below it; measured number above the stated range.
By their numbers in this assay, from the lowest: compound 2; then compound 1; then compound 3; then compound 4.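

In this assay the 1H-imidazol-2-yl on this aromatic carbon gives a 20-fold higher number from compound 3 to compound 4 (1.30 log units; beyond the scatter) and a 200-fold higher number from compound 2 to compound 4 (2.30 log units; beyond the scatter) and a 79-fold higher number from compound 1 to compound 4 (1.90 log units; beyond the scatter) and so stands apart from the three other five-membered rings. Compound 1 carries a hydrogen-bond donor on its 1H-pyrrol-2-yl too, so the donor count alone does not set the number here, and compound 3 matches compound 4 in heavy atoms and hetero atoms. Nothing at hand accounts for this gap. As far as these compounds go, how a methyl group on the imidazole ring nitrogen, or a pyridine ring, would read at this carbon stays open.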